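The compounds below may be only part of what the source reports. "The series", "measured", "known", "first", "only" and "open" are said of these compounds alone.

In a functional assay on HL-60 cells (Homo sapiens) for cytotoxicity, read by WST assay, with a stated time of 48 h (a higher number here means a weaker inhibitor, a lower number a stronger inhibitor), compound 1 `CC(C)C[C@]1(O)NC(=O)[C@]2(OC(Cc3ccccc3)=CC2=O)[C@H]1O` gives 28000 nM. Compound 2 `Cc1cc2c(c(=O)[nH]1)OC(C(=O)CC(C)C)O2` gives 19900 nM in this assay. For compound 3 `CC(C)CC(=O)C1Oc2cc(Cc3ccccc3)[nH]c(=O)c2O1`, this assay reports only a limit, > 50000 nM. The step of an at least 2.5-fold lower number from compound 3 to compound 2 (0.40 log units; beyond the scatter) rests on (hydrogen in place of phenyl on a saturated chain carbon bound to an aromatic carbon), and its true size is open because the starting point is the limit of > 50000 nM in this assay, at which 1 of the 3 values shown sits. The value of compound 1 lies close to that of compound 2. The difference between the core of compound 1 and the core of compound 3 is not broken down here. Compound 4 `CC1=CC(=O)[C@]2(O1)C(=O)N[C@@](O)(CC(C)C)[C@@H]2O` is still to be measured in this assay; it differs from compound 1 by hydrogen in place of phenyl on a saturated chain carbon bound to a double-bonded ring carbon, the same kind of change as between compound 3 and compound 2, though the place is a saturated chain carbon bound to a double-bonded ring carbon rather than one bound to an aromatic carbon. The step expected here, a 2.0-fold lower number from compound 1 to compound 4 (0.30 log units; within the scatter), is gauged against an at least 2.5-fold lower number from compound 3 to compound 2 (0.40 log units; beyond the scatter). The estimate for compound 4 in this assay is 14000 nM, between 5000 nM and 40000 nM.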

Compound 4, half-maximal inhibitory concentration: > 50000 nM
Compound 4 ended at the assay's limit; the forecaster's own chance of this, stated with the estimate: 10%; middle value at least 3.5-fold (0.55 log units) away from the limit.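

Hydrogen in place of phenyl, on a saturated chain carbon bound to a double-bonded ring carbon, gives an at least 1.7-fold higher number from compound 1 to compound 4 (0.25 log units; that floor lies within the scatter) in this assay. Set beside the earlier step, the change does not carry over unchanged from one core to the other: the same change on two cores in this assay, an at least 2.5-fold lower number (0.40 log units; beyond the scatter) from compound 3 to compound 2 and an at least 1.7-fold higher number (0.25 log units; that floor lies within the scatter) from compound 1 to compound 4, at least 4.4-fold (0.65 log units) apart, beyond the scatter of two such steps. This does not give the true size of either step or show why the two cores part, as each step rests on a limit: the limit of > 50000 nM in this assay, at which 2 of the 4 values shown sit.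

The compounds shown leave open whether a longer chain, or a benzyl group bearing a fluorine or a methoxy group, would follow either core. For the compounds shown here, with only two pairs, they also cannot say whether any other change would differ between these cores.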